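Methoxy to methyl on the thiazole aryl group

The source may report more compounds than this note shows. Statements on the series, on what has been measured and on what is new or still open speak of the compounds shown alone.

In an assay on isolated protein for inhibition of dual specificity protein phosphatase 3 (Homo sapiens), read by fluorescence, in the absence of a further agent (on this read-out higher numbers stand for weaker inhibition and lower numbers for stronger inhibition), compound 1 `COc1ccc(-c2csc(-c3cccc(NC(=O)C4CC4)c3)n2)cc1` gives 8900 nM, while compound 2 `COc1ccc(-c2nc(-c3ccc4c(c3)CCN4S(C)(=O)=O)cs2)cc1` gives 8100 nM. Compound 3 `COc1ccccc1-c1nc(-c2ccc3c(c2)CCN3S(C)(=O)=O)cs1` gives 2700 nM in this assay, the lowest of the three numbers; its nearest neighbour is compound 2, its furthest compound 1, and both gaps lie beyond the scatter. Going by the values given here, the one step among the measured compounds that touches the aryl group on the shared core is a 3.0-fold lower number from compound 2 to compound 3 (0.48 log units; beyond the scatter), a modest gain from moving the methoxy group around the ring.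

Compound 4 `Cc1cccc(-c2nc(-c3ccc4c(c3)CCN4S(C)(=O)=O)cs2)c1` differs from compound 3 by 3-methylphenyl in place of 2-methoxyphenyl on an aromatic carbon. Among the compounds with values here, no measured pair removes the methoxy oxygen altogether, so the step from compound 2 to compound 3 is the only guide, and it speaks only to where the methoxy group sits, not to its loss. With the acceptor gone and a methyl group entering at a third position, a drift back toward the range of compound 2 appears more likely than a further gain, but the size is uncertain and may stay within the scatter. For compound 4 the number in this assay is estimated at 5000 nM, between 2000 nM and 12000 nM. This estimate means a step of a 1.9-fold higher number from compound 3 to compound 4 (0.27 log units; within the scatter), expected to be small.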

Compound 4, half-maximal inhibitory concentration: 8000 nM
For compound 4 the middle estimate is 1.6-fold (0.20 log units) below the measured one, and the stated range covers the measured number.
By their numbers in this assay, from the lowest: compound 3; then compounds 4, 2 and 1 (each within the scatter of the next).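

At this position, the aromatic carbon next to the ring nitrogen and next to the ring sulfur, the replacement of 2-methoxyphenyl by 3-methylphenyl gives a 3.0-fold higher number from compound 3 to compound 4 (0.47 log units; beyond the scatter) in this assay, so the improvement seen in the earlier step (a 3.0-fold lower number from compound 2 to compound 3 (0.48 log units; beyond the scatter)) is not kept. 3-Methylphenyl and 4-methoxyphenyl cannot be told apart (a 1.0-fold lower number from compound 2 to compound 4 (0.01 log units; within the scatter)), which leaves 2-methoxyphenyl as the only one of the three aryl groups on the shared core with a number set apart from the other two, even though 3-methylphenyl carries no hydrogen-bond acceptor and 4-methoxyphenyl carries one. No supporting data bear on why 2-methoxyphenyl stands apart here.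

The step from compound 3 to compound 4 changes both the substituent and its place on the phenyl ring, so the effect of removing the methoxy oxygen cannot be separated from the effect of moving the group. 2-Methylphenyl and 3-methoxyphenyl at this position would separate those two changes, and 2-ethoxyphenyl would show whether the 2-substituted series extends beyond methoxy.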